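Swapping One Side Group on a Low-Number Compound

The source may hold more compounds than are shown below. What is called first, only, known or untested is meant among the compounds shown, and "the series" means these compounds.

In a functional assay on MV4-11 cells (Homo sapiens) for inhibition, read by luminescence, with a stated time of 72 h (a higher number here means a weaker inhibitor, a lower number a stronger inhibitor), compound 1 (`CC(=O)c1c(C)c2ccc(Nc3nccc(-c4cccnc4)n3)cc2oc1=O`) reads 12900 nM and compound 2 (`CCN1C(=O)COc2c(CN3CCN(S(C)(=O)=O)CC3)cc(Nc3ncc(F)c(-c4ccc(F)cc4OC)n3)cc21`) reads 15 nM as the lower of the two numbers, a gap well beyond the scatter of repeat measurements. Compound 3 (`CCN1C(=O)COc2c(CN(C)CCN(C)C)cc(Nc3ncc(F)c(-c4ccc(F)cc4OC)n3)cc21`) differs from compound 2 in one place ((2-(dimethylamino)ethyl)(methyl)amino in place of 4-(methylsulfonyl)piperazin-1-yl on a saturated chain carbon bound to an aromatic carbon). On a saturated chain carbon bound to an aromatic carbon, (2-(dimethylamino)ethyl)(methyl)amino stands in place of 4-(methylsulfonyl)piperazin-1-yl, so a ring gives way to an open chain. Among the compounds with values here, no measured pair shows this swap, and the rest of the structure is unchanged, which keeps the expectation anchored on compound 2 at 15 nM in this assay for now. The expected step is small, with a 1.3-fold lower number from compound 2 to compound 3 (0.10 log units; within the scatter) estimated to stay within the scatter. For compound 3 the estimate is 12 nM with an expected range of 3 nM to 50 nM in this span.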

Compound 3, half-maximal inhibitory concentration: 143 nM
For compound 3 the middle estimate is 12-fold (1.08 log units) below the measured one; the measured number lies above the stated range.
By their numbers in this assay, from the lowest: compound 2; then compound 3; then compound 1.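

At this position, the saturated chain carbon bound to an aromatic carbon, the choice of group matters in this assay: placing (2-(dimethylamino)ethyl)(methyl)amino where 4-(methylsulfonyl)piperazin-1-yl stood gives a 9.5-fold higher number from compound 2 to compound 3 (0.98 log units; beyond the scatter) and so moves the reading by more than repeat measurements would. Within the data shown here, compound 1 and compound 2 differ in many places, so this is the first comparison that isolates a single group here. No measurement at hand explains the step.

The swap removes the ring and the methylsulfonyl group together, so the compounds shown cannot tell which of the two changes carries the step. A 4-methylpiperazin-1-yl group or a morpholin-4-yl group at the same carbon would keep a ring without the methylsulfonyl group, and so could pull these two changes apart.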